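The source may hold more compounds than are shown below. What is called first, only, known or untested is meant among the compounds shown, and "the series" means these compounds.

Working notes on the series. Compound 2 `CCOC(=O)c1c(-c2ccccc2)[nH]c2cc(OC)ccc2c1=O`, compound 1 `CCOC(=O)c1c(-c2ccc(C(F)(F)F)cc2)[nH]c2cccc(OC)c2c1=O` and compound 3 `CCOC(=O)c1c(-c2cccc(F)c2)[nH]c2cccc(OC)c2c1=O` have been measured in a physicochemical assay for solubility, in phosphate buffer, at pH 7.4; a higher number here means a more soluble compound, a lower number a less soluble compound; compound 4 `CCOC(=O)c1c(-c2ccc(Cl)cc2)[nH]c2cc(OC)ccc2c1=O` has not. Compound 2 stands at a limit of the assay: in this assay compound 2 gives > 100000 nM, a limit and not a number. Compound 3 also sits at a limit, giving > 100000 nM in this assay. Compound 1 gives 22000 nM in this assay. The picture is framed by the limit of > 100000 nM in this assay, at which 2 of the 3 values shown sit. From compound 2 to compound 4 the change is chloro in place of hydrogen on an aromatic carbon. Among the measured compounds shown here, no step between measured compounds is available. A step downward in this assay, probably beyond the scatter, is expected, estimated as an at least 2.0-fold lower number from compound 2 to compound 4 (0.30 log units; that floor lies within the scatter). Compound 4 is expected to give 50000 nM in this assay, within 15000 nM to 150000 nM.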

Compound 4, solubility: 3000 nM
Compound 4: the middle estimate sits 17-fold (1.22 log units) above what was measured, outside the stated range (below it).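

In this assay, chloro in place of hydrogen, para to a large group, gives an at least 33-fold lower number from compound 2 to compound 4 (1.52 log units; beyond the scatter), so this position on the phenyl ring can respond strongly to a single heavy atom. As far as these compounds go, compound 2 gives > 100000 nM, a limit and not a number, so the step is a floor and its full size stays unknown. The range of the series remains bounded at the top: the limit of > 100000 nM in this assay, at which 2 of the 4 values shown sit.

From the compounds shown here alone, whether an amine or a carboxylic acid at this position would give a higher number than chloro stays open. Compound 1 and compound 3 differ from compound 4 in more than one place, so steps to them cannot be read.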